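The source may hold more compounds than are shown below. What is called first, only, known or untested is meant among the compounds shown, and "the series" means these compounds.

Compound 1 `Cc1ccc(S(=O)(=O)Nc2ccc3oc(-c4ccccc4)nc3c2)cc1` is one of three sulfonamides examined in an assay on isolated protein for inhibition of malate dehydrogenase, mitochondrial (Sus scrofa), with stated times of 45 min and 30 min; a lower number here means a stronger inhibitor, a higher number a weaker inhibitor. In this assay compound 1 gives > 63000 nM, which is a limit of the assay rather than a measured number. Compound 2 `O=S(=O)(Nc1ccc(-c2nc3ccccc3o2)cc1)c1ccc(F)c(C(F)(F)F)c1` gives > 63000 nM, likewise a limit. Compound 3 `O=S(=O)(Nc1ccc(-c2nc3ccccc3o2)cc1)c1ccccc1O` gives > 63000 nM, again a limit. All three values therefore sit at the limit of > 63000 nM in this assay, at which 3 of the 3 values shown sit, so compound 1 cannot be set apart from the others on these numbers. Compound 4 `CS(=O)(=O)Nc1ccc2oc(-c3ccccc3)nc2c1` differs from compound 1 in one place: methyl in place of 4-methylphenyl on a sulfonyl sulfur. Going by the values given here, no step between measured compounds is available to gauge this change. Since compound 1 rests at the limit of > 63000 nM in this assay, at which 3 of the 3 values shown sit, compound 4 is expected to stay at or near the limit, the expected step that the limit leaves unreadable from compound 1 to compound 4 showing no clear direction beyond the scatter. The estimate for compound 4 is 100000 nM, between 20000 nM and 500000 nM.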

Compound 4, half-maximal inhibitory concentration: > 63000 nM
Compound 4: no number, only a limit (the forecaster's own chance of this, stated with the estimate: 85%); the middle value is on the limit's open side.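

Going by these compounds alone, compound 1 and compound 4 each give only a limit, so no step between them can be read: the limit of > 63000 nM in this assay, at which 4 of the 4 values shown sit. The compounds shown leave open which structures would give a measurable value in this assay rather than a limit.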